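The source may report more compounds than this note shows. Statements on the series, on what has been measured and on what is new or still open speak of the compounds shown alone.

The compounds measured in a functional assay on LNCaP cells (Homo sapiens) for cytotoxicity (on this read-out higher numbers stand for an effect only at larger amounts of compound and lower numbers for an effect already at smaller amounts), are:

compound 1 `CCC[C@@H](OC(C)=O)C1=C(Br)[C@@](C)(OC)OC1=O`, compound 1 gives 1.7 ug/mL;
compound 2 `CCC[C@@H](OC(C)=O)C1=C(Br)[C@@](CI)(OC)OC1=O`, compound 2 gives 12.9 ug/mL;
compound 3 `CCC[C@@H](O)C1=C(Br)/C(=C\Br)OC1=O`, for compound 3 the value < 0.1 ug/mL is a limit of the assay, not a number.

Among the two numbers, compound 2 stands highest; its nearest neighbour is compound 1, and the step of a 7.6-fold higher number from compound 1 to compound 2 (0.88 log units; beyond the scatter) is beyond the scatter. The value of compound 3 is the limit of < 0.1 ug/mL in this assay, at which 1 of the 3 values shown sits, and so it gives no measure of distance from compound 2.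

Compound 4 `CCC[C@@H](OC(C)=O)C1=C(Br)[C@](OC)(C(Br)Br)OC1=O` is not yet measured. It differs from compound 2 in one place: dibromomethyl in place of iodomethyl on a saturated ring carbon. Going by the values given here, no measured step compares a dibromomethyl with an iodomethyl; the only measured step, a 7.6-fold higher number from compound 1 to compound 2 (0.88 log units; beyond the scatter), concerns the arrival of iodomethyl in place of hydrogen and is modest. Among the compounds with values here, because the step of a 7.6-fold higher number from compound 1 to compound 2 (0.88 log units; beyond the scatter) is the sole guide, and both compound 2 and compound 4 carry a halogenated methyl at the same place, the expected step of a 1.3-fold lower number from compound 2 to compound 4 (0.11 log units; within the scatter) is small, with no direction expected beyond the scatter. Compound 4 is therefore estimated at 10 ug/mL, with a range from 3 ug/mL to 35 ug/mL.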

Compound 4, concentration for half-maximal effect: 4.5 ug/mL
Beside the measured number, compound 4's estimate is 2.2-fold (0.35 log units) above it; low and high end bracket the measured number.
By their numbers in this assay, from the lowest: compound 1; then compound 4; then compound 2. At a limit, below all of these: compound 3.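

Compound 4 shows that, in this assay, the saturated ring carbon next to the ring oxygen distinguishes between halogenated methyl groups, which the earlier comparison of methyl with iodomethyl could not reveal: dibromomethyl in place of iodomethyl gives a 2.9-fold lower number from compound 2 to compound 4 (0.46 log units; beyond the scatter). Set against the methyl group, dibromomethyl gives a 2.6-fold higher number from compound 1 to compound 4 (0.42 log units; beyond the scatter), so compound 4 falls between the other two compounds, with both of its steps beyond the scatter, and among these three compounds the methyl compound keeps the lowest number. No measured property in the data bears on why dibromomethyl and iodomethyl differ in this way.

What the compounds shown leave open is whether the step from iodomethyl to dibromomethyl follows from the kind of halogen or from the degree of halogenation, a question that bromomethyl or diiodomethyl at the same ring carbon would help to separate. They also leave open how this position would respond to a group without halogen other than methyl, such as hydroxymethyl or aminomethyl, or to a longer chain such as ethyl.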